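From Dichlorophenyl to Pyridinyl: a Small Shift Expected

The source may hold more compounds than are shown below. What is called first, only, known or untested is meant among the compounds shown, and "the series" means these compounds.

Compound 1 `Nc1scc(CN2CCN(c3ccc(Cl)cc3Cl)CC2)c1C(=O)c1ccc(Cl)cc1` was tested in a functional assay on CHO cells with adenosine receptor A1 (Homo sapiens) as the target, read by cAMP accumulation and immunoassay, with a stated time of 6 min, tested at 0.01 uM (a higher number here means a weaker effect of the compound at the concentration tested, a lower number a stronger effect), where compound 1 gives 2%. For the measured compounds named here, of the two numbers measured so far, that of compound 1 is the smaller, though the gap to compound 2 lies within the scatter. Compound 2 `Nc1scc(CN2CCN(c3ccc(F)cc3Cl)CC2)c1C(=O)c1ccc(Cl)cc1` gives 6.1% in this assay; the step of a number 4.1 percentage points higher from compound 1 to compound 2 (within the scatter) comes from fluoro in place of chloro on an aromatic carbon. Compound 3 `Nc1scc(CN2CCN(c3cccnc3)CC2)c1C(=O)c1ccc(Cl)cc1` has not yet been measured in this assay. It differs from compound 1 by pyridin-3-yl in place of 2,4-dichlorophenyl on an amine nitrogen in a ring. Going by the values given here, no measured step involves the same kind of change; the only step available concerns that same ring and left the number essentially unchanged, so there is little ground for expecting a large move. Compound 3 is therefore expected to sit close to compound 1, with the estimated step of a number 3 percentage points higher from compound 1 to compound 3 (within the scatter). The estimate for compound 3 in this assay is 5%, within a range from -6% to 18%.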

Compound 3, a percentage reported as activity, at one concentration (the size of the read-out at that concentration, not a potency): 3.2%
Compound 3: the middle estimate sits 1.8 percentage points above what was measured; measured number inside the range.
By their numbers in this assay, from the lowest: compounds 1, 3 and 2 (each within the scatter of the next).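

Until now, this position had only shown a swap of one halogen for another. Replacing the whole 2,4-dichlorophenyl with pyridin-3-yl is a broader change, removing both chlorines and bringing in a ring nitrogen, yet in this assay it gives a number 1.2 percentage points higher from compound 1 to compound 3 (within the scatter) and, from the fluorinated analogue, a number 2.9 percentage points lower from compound 2 to compound 3 (within the scatter) in the same assay. At the single concentration tested, this assay therefore does not distinguish pyridin-3-yl from either halogenated phenyl on this amine nitrogen.

No measurement shown explains why these compounds read alike. Also open, on these data alone, is whether a different kind of group at this place, such as a carboxylic acid or a longer alkyl chain, would give a number clearly apart from these three.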